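This account rests on a few compounds, and the source may have more. Where it says the series, first, only, none or still open, it means among the compounds named here.

Measured compounds:
- Compound 1, `CN(Cc1ccc(N(C)C)cc1)Cc1cccc(CNc2ccnc3cc(Cl)ccc23)c1`, 7.36
- Compound 2, `COc1ccc(CN(C)Cc2ccc(CNc3ccnc4cc(Cl)ccc34)cc2)cc1`, 7.44
- Compound 3, `COc1ccc(CN(C)Cc2cccc(CNc3ccnc4cc(Cl)ccc34)c2)cc1`, 7.38

Three compounds have so far been run through a physicochemical assay for acid dissociation. Compound 2 has the highest of the three numbers, but its gap to compound 3 and its gap to compound 1 both lie within the usual scatter of such measurements, so no order among them can be claimed. Compound 2 and compound 3 are built from the same atoms joined differently; the difference between the two cores is not broken down here.

One structural change has been measured directly: going from compound 3 to compound 1, (dimethylamino in place of methoxy on an aromatic carbon). The step that came with it was a number 0.02 log units lower from compound 3 to compound 1 (within the scatter), that is, essentially no movement.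

Compound 4, `CN(Cc1ccc(CNc2ccnc3cc(Cl)ccc23)cc1)Cc1ccc(N(C)C)cc1`, has not yet been measured in this assay. It arises from compound 2 by the same change: dimethylamino in place of methoxy on an aromatic carbon. Among the measured compounds shown here, since the one earlier example of this change, from compound 3 to compound 1, gave a step of a number 0.02 log units lower from compound 3 to compound 1 (within the scatter), a similarly flat step is expected here. The expected step from compound 2 to compound 4 is a number 0.02 log units lower from compound 2 to compound 4 (within the scatter). On that basis compound 4 is estimated to give 7.42 in this assay, with a likely range from 7.2 to 7.65.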

Compound 4, acid dissociation constant: 7.33
For compound 4 the middle estimate is 0.09 log units above the measured one, and the stated range covers the measured number.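

In this assay, placing dimethylamino where methoxy stood on an aromatic carbon gives a number 0.11 log units lower from compound 2 to compound 4 (within the scatter), and the same change on the other core gave a number 0.02 log units lower from compound 3 to compound 1 (within the scatter), so in both pairs the step stays within the scatter and the change carries from one core to the other as a flat step. Among the compounds shown here, this rests on only two pairs, so it shows agreement between these two cores and does not show that the step would stay flat on a third core; it also cannot rule out a small true shift, as steps of this size cannot be told apart from the differences seen between repeated measurements. Nothing available explains why the number stays flat in either pair.

The compounds shown leave open how a primary amine, a carboxylic acid or a trifluoromethyl group would read in this assay if placed on the same six-membered aromatic ring of carbon only, as the only swap shown there is methoxy to dimethylamino. They also leave open whether this flat step would hold on a core with a longer chain leading to that ring.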